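From trifluoromethyl to methylamino on the shared core

The source may report more compounds than this note shows. Statements on the series, on what has been measured and on what is new or still open speak of the compounds shown alone.

Going by the values given here, in a physicochemical assay for solubility, measured as kinetic solubility, at pH 2 (a lower number here means a less soluble compound, a higher number a more soluble compound), compound 2 `COc1ccc(-c2cc(-c3ccc(S(C)(=O)=O)cc3)cnc2C(F)(F)F)cn1` gives 12.5 ug/mL as the only actual number so far. Compound 1 `COc1ccc(-c2cc(-c3ccc(S(C)(=O)=O)cc3)cnc2NCCCCN)cn1` gives > 100 ug/mL as its reading, and this is a limit of the assay, not a number.

Compound 3 `CNc1ncc(-c2ccc(S(C)(=O)=O)cc2)cc1-c1ccc(OC)nc1` is next. It carries methylamino in place of trifluoromethyl on an aromatic carbon and otherwise matches compound 2.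

Among the compounds with values here, one measured step bears on this change: an at least 8.0-fold lower number from compound 1 to compound 2 (0.90 log units; beyond the scatter) when trifluoromethyl takes the place of (4-aminobutyl)amino on an aromatic carbon. Compound 3 undoes that step only in part, since methylamino enters rather than (4-aminobutyl)amino. Within the data shown here, no compound yet separates the effect of the chain from that of the group as a whole, so the full size of the measured step is not carried over.

A move to a higher number in this assay is expected, with a 3.2-fold higher number from compound 2 to compound 3 (0.51 log units; beyond the scatter) as the estimated step. The estimated value for compound 3 is 40 ug/mL within an expected range from 15 ug/mL to 100 ug/mL in this assay.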

Compound 3, solubility: > 100 ug/mL
Compound 3: a limit, no number (the forecaster's own chance of this, stated with the estimate: 20%); at least 2.5-fold (0.39 log units) between middle value and limit.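

In this assay, methylamino in place of trifluoromethyl on an aromatic carbon next to the ring nitrogen gives an at least 8.0-fold higher number from compound 2 to compound 3 (0.90 log units; beyond the scatter). Compound 3 reads > 100 ug/mL, which is a limit of the assay and not a number. The earlier compounds shown here could not separate the long chain of compound 1 from the nitrogen joined to the aromatic carbon, whereas compound 3 now shows that the 3-aminopropyl part is not required for a reading at the limit at this position, and that methylamino is enough to leave the trifluoromethyl reading well behind.

The step between compound 1 and compound 3 cannot be read, and any difference between the two amino groups stays hidden: the limit of > 100 ug/mL in this assay, at which 2 of the 3 values shown sit. Open questions are whether a plain amino group, a dimethylamino group with no hydrogen on the nitrogen, or a methoxy group with oxygen in place of the nitrogen would also reach the limit, and how much of the step depends on the nitrogen rather than on the loss of trifluoromethyl.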